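Fluorine for hydrogen: the expected lipophilicity of compound 4

The source may report more compounds than this note shows. Statements on the series, on what has been measured and on what is new or still open speak of the compounds shown alone.

Compound 3 `S=C(N/N=C/c1ccc(Oc2ccccc2)cc1)Nc1ccccc1` is the plainest member of this small series. Among the measured compounds shown here, in a physicochemical assay for lipophilicity, in phosphate buffer, measured as octanol-water partition, with a stated time of 24 h (a higher number here means a more lipophilic compound, a lower number a more polar compound), compound 3 gives 4.9, the lowest of the three numbers measured so far. Compound 1 `Cc1ccc(Oc2ccc(/C=N/NC(=S)Nc3ccccc3)cc2)cc1` carries a methyl group where compound 3 has only a hydrogen, and in this assay compound 1 gives 5.39. That single step is a number 0.49 log units lower from compound 1 to compound 3 (beyond the scatter). For the measured compounds named here, compound 2 `Fc1ccc(Oc2ccc(/C=N/NC(=S)Nc3ccc(Br)cc3)cc2)cc1` differs from compound 3 at two places, with a fluoro group and a bromo group, and in this assay compound 2 gives 5.82; no single step joins it to compound 3, so its value can only be noted. Compound 4 `Fc1ccc(Oc2ccc(/C=N/NC(=S)Nc3ccccc3)cc2)cc1` is the next step: fluoro in place of hydrogen on an aromatic carbon. Going by the values given here, none of the measured steps introduces a fluoro group on its own; the only single step available, from compound 1 to compound 3, shows how much a small group on that ring can shift the number. A small rise in this assay is therefore expected, a number 0.20 log units higher from compound 3 to compound 4 (within the scatter). For compound 4 the expected value is 5.1, within a range from 4.8 to 5.5.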

Compound 4, partition coefficient: 5.09
Estimate against measurement, compound 4: 0.01 log units above; the range from low to high includes it.
By their numbers in this assay, from the lowest: compounds 3, 4 and 1 (each within the scatter of the next, the first and the last beyond it); then compound 2.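

In this assay, fluoro on this aromatic carbon, para to a large group, gives a number 0.19 log units higher from compound 3 to compound 4 (within the scatter) and so cannot be told apart from hydrogen there, while fluoro in place of methyl at that carbon gives a number 0.30 log units lower from compound 1 to compound 4 (within the scatter) as well. Among the compounds shown here, the bromo group could not be read on its own before, but now it can: taking it away gives a number 0.73 log units lower from compound 2 to compound 4 (beyond the scatter) and is the only one of the new steps that clears the scatter. No other measurement bears on why these steps differ in size.

From the compounds shown here alone, whether a chloro group, an amine or a carboxylic acid at the fluoro position would move the number beyond the scatter stays open. Going by these compounds, whether the bromo step would keep its size without the fluoro group also stays open.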